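Aryl swap on the ring nitrogen: compound 3 to compound 4

A few compounds are considered here, and "the series" means these few. Any claim that something is new, unique, unknown or untested is made for them only; others in the source may bear on it.

In a functional assay on A-431 cells (Homo sapiens) for antiproliferative activity, read by MTT assay, with a stated time of 72 h (on this read-out higher numbers stand for weaker inhibition and lower numbers for stronger inhibition), three members of the series carry numbers. Compound 1 `COc1cccc(Nc2ncnc3cc(OC)c(OCCCN4CCNCCNCCNCC4)cc23)c1` gives 3210 nM, compound 2 `COc1cc2ncnc(Nc3ccc(C#N)cc3F)c2cc1OCCCN1CCNCCNCCNCC1` gives 6370 nM, and compound 3 `COc1cc2ncnc(Nc3cccc(Br)c3)c2cc1OCCCN1CCNCCNCC1` gives 2320 nM. Compound 3 holds the lowest of the three numbers; its gap to compound 1 lies within the scatter, while compound 2 sits beyond it. Going by the values given here, the one measured change at this nitrogen, a 2.0-fold higher number from compound 1 to compound 2 (0.30 log units; within the scatter), stayed within the scatter.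

Compound 4 `COc1cc2ncnc(Nc3ccc(Cl)cc3Cl)c2cc1OCCCN1CCNCCNCC1` differs from compound 3 by 2,4-dichlorophenyl in place of 3-bromophenyl on a nitrogen on an aromatic ring. Among the compounds with values here, no measured pair exchanges a 3-bromophenyl for a 2,4-dichlorophenyl, so the only bearing comes from the change of aryl group between compound 1 and compound 2, which was within the scatter. On that basis the step of a 1.5-fold higher number from compound 3 to compound 4 (0.18 log units; within the scatter) is expected to be small and, if anything, toward a higher number, with no direction claimed beyond the scatter. Compound 4 is therefore estimated at 3500 nM, with a range from 1200 nM to 10000 nM.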

Compound 4, half-maximal inhibitory concentration: 4080 nM
For compound 4 the middle estimate is 1.2-fold (0.07 log units) below the measured one; the range from low to high includes it.
By their numbers in this assay, from the lowest: compounds 3, 1, 4 and 2 (each within the scatter of the next, the first and the last beyond it).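

In this assay, going by these compounds alone, the exchange of 3-bromophenyl for 2,4-dichlorophenyl on the nitrogen gives a 1.8-fold higher number from compound 3 to compound 4 (0.25 log units; within the scatter) and is the first aryl exchange read on the side chain of compound 3. The exchange between compound 1 and compound 2, on a different side chain, also stayed within the scatter, so neither side chain yet shows a step at this nitrogen that stands clear of it, even though 2,4-dichlorophenyl brings one more heavy atom than 3-bromophenyl. No available evidence accounts for the size of this step.

Going by these compounds, whether a phenyl ring carrying an amine or a carboxylic acid on this nitrogen would give a step beyond the scatter remains open. On these data alone, the effect of the side chain alone also remains open, as does that of a longer chain joining it to the core.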